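The compounds below may be only part of what the source reports. "The series", "measured", "known", "first", "only" and "open" are said of these compounds alone.

Measured in a functional assay on ECa-109 cells for inhibition, with ECa-109 cell line (Homo sapiens) as the target, read by sulforhodamine B assay; on this read-out higher numbers stand for weaker inhibition and lower numbers for stronger inhibition:
Compound 1 `COc1ccccc1NC1=CC(=O)c2nc3n(c2C1=O)[C@H]1OC[C@@H](O)[C@H]1OC3`: > 4000 nM (a limit)
Compound 2 `O=C1C=C(Nc2ccc(C(F)(F)F)cc2)C(=O)c2c1nc1n2[C@H]2OC[C@@H](O)[C@H]2OC1`: 5500 nM
Compound 3 `Cc1ccc(NC2=CC(=O)c3nc4n(c3C2=O)[C@H]2OC[C@@H](O)[C@H]2OC4)cc1C`: 2820 nM

Among the compounds with values here, compound 3 gives 2820 nM, and the only other true number belongs to compound 2, at 5500 nM. The two sit within the scatter of each other, with a 2.0-fold lower number from compound 2 to compound 3 (0.29 log units; within the scatter). Compound 1 gives only a limit, > 4000 nM. Compound 4 `O=C1C=C(Nc2cccc(Cl)c2)C(=O)c2c1nc1n2[C@H]2OC[C@@H](O)[C@H]2OC1` keeps the shared core and carries 3-chlorophenyl in place of 3,4-dimethylphenyl on an amine nitrogen.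

All three measured steps exchange the group at this same nitrogen. Within the data shown here, the one between true numbers is a 2.0-fold lower number from compound 2 to compound 3 (0.29 log units; within the scatter). The others are an at least 1.4-fold lower number from compound 1 to compound 3 (0.15 log units; that floor lies within the scatter) and a step that the limit leaves unreadable from compound 1 to compound 2, and both rest on the limit (the limit of > 4000 nM in this assay, at which 1 of the 3 values shown sits). None of them shows a change beyond the scatter, so none is expected here in this assay. The expected step is a 1.2-fold higher number from compound 3 to compound 4 (0.09 log units; within the scatter). For compound 4 the estimated value is 3500 nM, with an expected range from 1700 nM to 7000 nM.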

Compound 4, half-maximal inhibitory concentration: 4690 nM
Beside the measured number, compound 4's estimate is 1.3-fold (0.13 log units) below it; the range from low to high includes it.
By their numbers in this assay, from the lowest: compounds 3, 4 and 2 (each within the scatter of the next).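

In this assay, 3-chlorophenyl on the amine nitrogen gives a number that cannot be told apart from those of the two neighbouring aryl groups: a 1.7-fold higher number from compound 3 to compound 4 (0.22 log units; within the scatter), and a 1.2-fold lower number from compound 2 to compound 4 (0.07 log units; within the scatter). Compounds 2, 3 and 4 thus carry three differently substituted phenyl groups at this nitrogen, a chlorine among them, and none of the readable steps between them goes beyond the scatter. The step from compound 1 to compound 4 cannot be read, as compound 1 gives only a limit: the limit of > 4000 nM in this assay, at which 1 of the 4 values shown sits.

The compounds shown leave open whether a group of another kind on this nitrogen, such as a carboxylic acid, an amine or a longer alkyl chain in place of the phenyl ring, would move the number beyond the scatter. They also leave open whether any change away from this nitrogen would do so.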